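Swapping furan-3-yl for thiophen-2-yl on the shared core

A few compounds are considered here, and "the series" means these few. Any claim that something is new, unique, unknown or untested is made for them only; others in the source may bear on it.

Of the compounds shown here, two of this set have been measured in an assay on membranes from CHO cells for displacement of a labelled ligand from adenosine receptor A1 (Homo sapiens), read by scintillation counting, with a stated time of 60 min, tested at 1 uM; on this read-out lower numbers stand for less inhibition and higher numbers for more inhibition at the one concentration tested (going by the name of the read-out). Compound 1 `CCC(C)OC(=O)C1=C(C)NC(=O)NC1c1ccco1` gives 6% in this assay, and compound 2 `CCC(C)OC(=O)C1=C(C)NC(=O)NC1c1ccoc1` gives 13%. Going by the values given here, the one step between them, a number 7 percentage points higher from compound 1 to compound 2 (within the scatter), shows that the two numbers sit within the scatter of each other, so neither compound can be called stronger than the other. Compound 3 `CCC(C)OC(=O)C1=C(C)NC(=O)NC1c1cccs1` has not yet been measured. It differs from compound 2 in one place: thiophen-2-yl in place of furan-3-yl on a saturated ring carbon. Among the compounds with values here, no measured step exchanges a furan-3-yl for a thiophen-2-yl, so the single step in hand bears on this change only loosely, and that step was itself within the scatter. In this assay the step that the estimate means, a number 2 percentage points lower from compound 2 to compound 3 (within the scatter), is expected to stay within the scatter. For compound 3 the estimate in this assay is 11%, with a range from 0% to 26%.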

Compound 3, a percentage reported as inhibition, at one concentration (the size of the read-out at that concentration, not a potency): 5%
The estimate for compound 3 lay 6 percentage points above the measured number, and the stated range covers the measured number.
By their numbers in this assay, from the lowest: compounds 3, 1 and 2 (each within the scatter of the next).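

With a thiophen-2-yl on this saturated ring carbon, this assay gives a number 8 percentage points lower from compound 2 to compound 3 (within the scatter) and also a number 1 percentage points lower from compound 1 to compound 3 (within the scatter). Furan-2-yl, furan-3-yl and thiophen-2-yl therefore cannot be told apart here, so neither moving the ring oxygen nor exchanging a furan for a ring with sulfur shifts the number beyond the scatter in these compounds. No separate measurement bears on this result.

From the compounds shown here alone, whether a different kind of group on this carbon, such as a phenyl ring, an amine or a longer alkyl chain, would give a number beyond the scatter remains open. Also open, going by these compounds, is whether these three rings would still read alike at another concentration or on a core carrying a different ester.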